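This account rests on a few compounds, and the source may have more. Where it says the series, first, only, none or still open, it means among the compounds named here.

Measured compounds in a functional assay on HEL cells (Homo sapiens) for cytotoxicity, read by microscopy; a lower number here means that less compound is tolerated, a higher number that more compound is tolerated:
- compound 1, `Cc1cn([C@@H]2O[C@H](CO[Si](C)(C)C(C)(C)C)[C@@]3(OS(=O)(=O)C=C3NC(=O)c3ccccc3)[C@H]2O[Si](C)(C)C(C)(C)C)c(=O)n(C)c1=O`; in this assay compound 1 gives >= 3200 nM, which is a limit of the assay and not a number.
- compound 2, `COC(=O)CC(=O)NC1=CS(=O)(=O)O[C@@]12[C@@H](CO[Si](C)(C)C(C)(C)C)O[C@@H](n1cc(C)c(=O)n(C)c1=O)[C@@H]2O[Si](C)(C)C(C)(C)C`; in this assay compound 2 gives 400000 nM.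
- compound 3, `Cc1cn([C@@H]2O[C@H](CO[Si](C)(C)C(C)(C)C)[C@@]3(OS(=O)(=O)C=C3NCC(=O)C(=O)N3CCC3)[C@H]2O[Si](C)(C)C(C)(C)C)c(=O)n(C)c1=O`; in this assay compound 3 gives 65000 nM.

Compound 3 holds the lowest of the two numbers; its nearest neighbour is compound 2, and the move is a 6.2-fold lower number from compound 2 to compound 3 (0.79 log units; beyond the scatter). The steps a step that the limit leaves unreadable from compound 1 to compound 2 and a step that the limit leaves unreadable from compound 1 to compound 3 cannot be sized, since compound 1 sits at the limit of >= 3200 nM in this assay, at which 1 of the 3 values shown sits.

Compound 4, `Cc1cn([C@@H]2O[C@H](CO[Si](C)(C)C(C)(C)C)[C@@]3(OS(=O)(=O)C=C3NCC(=O)OCc3ccccc3)[C@H]2O[Si](C)(C)C(C)(C)C)c(=O)n(C)c1=O`, is the next member. The change from compound 3 is benzyloxy in place of (azetidin-1-yl)carbonyl on a carbonyl carbon.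

Among the compounds with values here, only one measured step bears on this: the move from compound 2 to compound 3 replaces a ((methoxycarbonyl)methyl)carbonyl group on the amine nitrogen and lowers the number by a modest amount. Compound 4 carries a (benzyloxycarbonyl)methyl group on that nitrogen, and its oxygen-bearing carbonyl resembles the arrangement found in compound 2 more than the ((azetidin-1-yl)carbonyl)carbonyl group of compound 3. A return toward the number of compound 2 is therefore expected, of a size comparable to a 6.2-fold lower number from compound 2 to compound 3 (0.79 log units; beyond the scatter) but in the opposite direction, with the step of a 2.3-fold higher number from compound 3 to compound 4 (0.36 log units; beyond the scatter) estimated for compound 4.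

Compound 4 is expected to give 150000 nM, within a range of 40000 nM to 400000 nM.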

Compound 4, minimum cytotoxic concentration: >= 400000 nM
Compound 4 was reported as a limit (the forecaster's own chance of this, stated with the estimate: 25%); middle value at least 2.6-fold (0.42 log units) away from the limit.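

With the methylene on the amine nitrogen held constant in compound 3 and compound 4, changing only the group on the carbonyl carbon gives an at least 6.1-fold higher number from compound 3 to compound 4 (0.78 log units; beyond the scatter), so the read-out at this position responds to that group alone, without any change at the amine nitrogen itself. In this assay compound 4 gives >= 400000 nM, which is a limit of the assay and not a number. The data also give a number no lower from compound 2 to compound 4 (the limit leaves the size open). The step to compound 4 from compound 1 cannot be read in size, and among the compounds with a full number the only one lower than the rest remains the one carrying the (azetidin-1-yl)carbonyl group: the limit of >= 400000 nM in this assay, at which 1 of the 4 values shown sits.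

From the compounds shown here alone, whether the step follows from the loss of the (azetidin-1-yl)carbonyl group or from the arrival of the benzyloxy group remains open, as does how far the true number of compound 4 lies past its limit. A carboxylic acid, a dimethylamino group or an azetidin-1-yl group placed directly on the same carbonyl carbon would help separate those two readings.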